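Adding one hydroxy to compound 1

The compounds below may be only part of what the source reports. "The series", "measured", "known", "first", "only" and "open" are said of these compounds alone.

Compound 1 `N=C(N)c1ccc(-c2cc3ccc(C(=N)N)cc3o2)cc1`: 800 nM
Compound 2 `Oc1cc(C2=NCCN2)cc2cc(-c3ccc(C4=NCCN4)cc3)oc12`: > 203000 nM, a limit of the assay

Among the measured compounds shown here, in an ADME assay on L6 cells (Rattus norvegicus) for cytotoxicity (on this read-out higher numbers stand for weaker inhibition and lower numbers for stronger inhibition), compound 1 gives 800 nM, the only exact number available so far. Compound 2 has only a limit, > 203000 nM, and not a number. The next compound to be tested is compound 3 `N=C(N)c1ccc(-c2cc3ccc(C(=N)N)cc3o2)c(O)c1`. It has the same core as compound 1, with one change: hydroxy in place of hydrogen on an aromatic carbon. This carbon belongs to a six-membered aromatic ring of carbon only, and it lies ortho to a large group and meta to a group of 3 heavy atoms.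

For the measured compounds named here, no two measured compounds differ in just one place, so the data give no direct measure of what such a change does. Starting from compound 1 at 800 nM, a moderate step towards higher numbers in this assay is expected, which would mean weaker inhibition. The expected size of this change is a 3.1-fold higher number from compound 1 to compound 3 (0.49 log units; beyond the scatter). For compound 3 the estimate is 2500 nM, with an expected range from 500 nM to 15000 nM.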

Compound 3, half-maximal inhibitory concentration: > 221000 nM
Compound 3 was reported as a limit (the forecaster's own chance of this, stated with the estimate: 8%); middle value at least 88-fold (1.94 log units) away from the limit.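

In this assay, one hydroxy in place of hydrogen, on an aromatic carbon ortho to a large group and meta to a group of 3 heavy atoms, gives an at least 270-fold higher number from compound 1 to compound 3 (2.44 log units; beyond the scatter), the only direct measure of a single change among the compounds shown. Among the compounds shown here, this position is therefore far from indifferent: on this read-out, the one added group moves the compound from a measurable value to much weaker inhibition of the cells, although the data do not say why. Compound 3 carries a limit of the assay and not a number, so the step fixes only a minimum size and its full size remains unknown: the limit of > 221000 nM in this assay, at which 1 of the 3 values shown sits.

On these data alone, what remains open is whether this large step belongs to the hydroxy itself or would appear with other groups, and a methoxy or a fluorine on the same carbon would help to separate those two readings. As far as these compounds go, it is also open whether a hydroxy on a different carbon of this ring would give a step of similar size, and compound 2 cannot answer this, as it differs from compound 1 in more than one place.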